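This account rests on a few compounds, and the source may have more. Where it says the series, first, only, none or still open, it means among the compounds named here.

Measured so far in a functional assay (trachea) with Cavia porcellus as the target; a lower number here means a stronger inhibitor, a higher number a weaker inhibitor:
Compound 1 `Oc1nnc(-c2cccnc2)c2ccccc12`: 10200 nM
Compound 2 `CCn1nc(-c2cccnc2)c2ccccc2c1=O`: 1320 nM
Compound 3 `O=c1c2ccccc2c(-c2cccnc2)nn1C1CCCC1`: 2750 nM

Among these three, compound 3 has the second highest number. It lies above compound 2 and below compound 1, and both gaps are beyond the scatter.

The compound still to be measured is compound 4 `CCOC(=O)CCCn1nc(-c2cccnc2)c2ccccc2c1=O`, which carries 3-(ethoxycarbonyl)propyl in place of cyclopentyl on an aromatic nitrogen. The difference is this: 3-(ethoxycarbonyl)propyl in place of cyclopentyl on an aromatic nitrogen.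

Among the measured compounds shown here, one measured step bears on this change. It is a 2.1-fold higher number from compound 2 to compound 3 (0.32 log units; beyond the scatter) and it swaps ethyl for cyclopentyl on an aromatic nitrogen. That step is modest, although it lies beyond the scatter. For the measured compounds named here, no measured compound carries 3-(ethoxycarbonyl)propyl, so the data offer no direct guide to it and the direction remains uncertain. The entering group has no ring, like the ethyl of compound 2 at 1320 nM in this assay, which gives a slight lean towards a lower number. Even so, no step beyond the scatter is expected. The estimate amounts to a 1.4-fold lower number from compound 3 to compound 4 (0.14 log units; within the scatter) as the expected change in this assay for this swap. For compound 4 the expected value is 2000 nM in this assay, with an estimated range from 700 nM to 6000 nM for a first measurement.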

Compound 4, half-maximal inhibitory concentration: 10000 nM
Estimate against measurement, compound 4: 5.0-fold (0.70 log units) below, and the stated range ends below it.
By their numbers in this assay, from the lowest: compound 2; then compound 3; then compounds 4 and 1 (each within the scatter of the next).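

In this assay the open chain did not behave like the ethyl of compound 2, so the absence of a ring on the aromatic nitrogen was not enough to keep the number low. The change gave a 3.6-fold higher number from compound 3 to compound 4 (0.56 log units; beyond the scatter) and, measured against the ethyl compound, a 7.6-fold higher number from compound 2 to compound 4 (0.88 log units; beyond the scatter) for a chain extended with an ethyl ester at its end. Compound 4 at 10000 nM and compound 1 at 10200 nM lie within the scatter of each other, which shows that this substituent on the nitrogen can cost all of the gain seen with ethyl, and nothing available explains the shift.

The compounds shown do not separate the length of the chain from the ester at its end, so a plain butyl chain would be needed to tell the two apart. From the compounds shown here alone, whether a carboxylic acid, an amide or an amine at the end of the same chain would give a number nearer to that of compound 2 also remains open.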